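The source may report more compounds than this note shows. Statements on the series, on what has been measured and on what is new or still open speak of the compounds shown alone.

In a functional assay on SW-620 cells (Homo sapiens) for cytotoxicity, read by MTT assay, with a stated time of 72 h (a higher number here means a weaker inhibitor, a lower number a stronger inhibitor), compound 1 (`COc1ccc(/C=C2\CCC/C(=C\c3cccc(Cl)c3)C2=O)cc1OC`) gives 5100 nM while compound 2 (`COc1ccccc1/C=C1\CCC/C(=C\c2ccc(OC)c(OC)c2)C1=O`) gives 7800 nM and compound 3 (`COc1cccc(/C=C2\CCC/C(=C\c3ccc(OC)c(OC)c3)C2=O)c1`) gives 3700 nM on the same scale. Compound 3 stands at the low end of this small set, with a 1.4-fold lower number from compound 1 to compound 3 (0.14 log units; within the scatter) and a 2.1-fold lower number from compound 2 to compound 3 (0.32 log units; beyond the scatter) as its gaps. Compound 4 (`COc1ccc(/C=C2\CCC/C(=C\c3ccc(O)cc3)C2=O)cc1OC`) is still unmeasured, and its change is 4-hydroxyphenyl in place of 3-methoxyphenyl on a double-bonded chain carbon bound to a double-bonded ring carbon in all: 4-hydroxyphenyl in place of 3-methoxyphenyl on a double-bonded chain carbon bound to a double-bonded ring carbon. Swaps at this place have moved the number little: a 1.5-fold higher number from compound 1 to compound 2 (0.18 log units; within the scatter) stays within the scatter, and only a 2.1-fold lower number from compound 2 to compound 3 (0.32 log units; beyond the scatter) passes it, modestly. Among the measured compounds shown here, no measured compound carries a hydroxy group, so the step in this assay is expected to stay within the scatter, perhaps slightly upward. That expectation amounts to a 1.2-fold higher number from compound 3 to compound 4 (0.07 log units; within the scatter) as an estimate. For compound 4 the expected value is 4300 nM within an estimated range of 1700 nM to 10000 nM for now.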

Compound 4, half-maximal inhibitory concentration: 7700 nM
Compound 4: middle estimate off by 1.8-fold (0.25 log units), on the low side, within the range that was stated.
By their numbers in this assay, from the lowest: compounds 3, 1, 4 and 2 (each within the scatter of the next, the first and the last beyond it).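

In this assay, 4-hydroxyphenyl is the first group shown at this place with a hydrogen-bond donor, and it gives a 2.1-fold higher number from compound 3 to compound 4 (0.32 log units; beyond the scatter). The other two comparisons stay within the scatter, with a 1.0-fold lower number from compound 2 to compound 4 (0.01 log units; within the scatter) and a 1.5-fold higher number from compound 1 to compound 4 (0.18 log units; within the scatter). Among the compounds shown here, the only steps beyond the scatter at this place now both involve compound 3, and no measurement available here explains them.

This step changes both the group and where it sits on the aromatic ring, so the two effects cannot be separated. A 3-hydroxyphenyl or an aminophenyl group at this place would remain to be compared.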